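This account rests on a few compounds, and the source may have more. Where it says the series, first, only, none or still open, it means among the compounds named here.

Two compounds have been measured in an assay on microsomes from intestinal mucosa for inhibition of acyl-CoA:cholesterol acyltransferase (Oryctolagus cuniculus); on this read-out higher numbers stand for weaker inhibition and lower numbers for stronger inhibition:

compound 1, `CCCCCCCCCCCCCCCCCCNC(=O)Nc1c(C(C)C)cccc1C(C)C`: 48 nM
compound 2, `CCCCCCCCCCCCCCNC(=O)Nc1ccc(F)cc1F`: 340 nM

Of these two numbers, compound 1 holds the lower one, and its gap to compound 2 lies beyond the usual scatter. Compound 3, `CCCCCCCCCCNC(=O)Nc1c(C(C)C)cccc1C(C)C`, keeps the core of compound 1 and differs from it only in the chain: hydrogen in place of octyl on a saturated chain carbon, ten or more bonds along the chain from an amide-type nitrogen. For the measured compounds named here, no measured pair shows this change by itself, so its size is not known from the data. Compound 2 carries a chain shorter than that of compound 1 on a different core, so its number says nothing direct about the chain alone. He expects the shortening to weaken inhibition, with a step of a 6.3-fold higher number from compound 1 to compound 3 (0.80 log units; beyond the scatter) that goes beyond the scatter. For compound 3 in this assay he therefore estimates 300 nM, within a range from 80 nM to 1500 nM.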

Compound 3, half-maximal inhibitory concentration: 56 nM
Estimate against measurement, compound 3: 5.4-fold (0.73 log units) above; measured number below the stated range.
By their numbers in this assay, from the lowest: compounds 1 and 3 (each within the scatter of the next); then compound 2.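

In this assay, hydrogen in place of octyl on a saturated chain carbon, ten or more bonds along the chain from an amide-type nitrogen, gives a 1.2-fold higher number from compound 1 to compound 3 (0.07 log units; within the scatter) and so shows no separable change. On the core of compound 1, the outer stretch of the chain can therefore go without a difference this read-out can resolve, which the earlier pair could not show, as its two compounds differ in both chain and core. Nothing available here accounts for this result.

Going by these compounds, what remains open is how far the chain can be shortened on this core before inhibition changes, a question that a hexyl chain would address. On these data alone, it is also open whether a carboxylic acid or an amine at the chain end would leave the number where it is.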